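The compounds below may be only part of what the source reports. "The series", "measured", "known", "first", "only" and "open" are said of these compounds alone.

Compound 2 `ClCc1ccccc1Cn1cnc2c(Cl)nc(Cl)nc21` was tested in a functional assay on M14 cells (Homo sapiens) for cytotoxicity, read by sulforhodamine B assay, with a stated time of 48 h (a higher number here means a weaker inhibitor of growth, a lower number a stronger inhibitor of growth), and gave 2810 nM. Of the two numbers recorded so far it is the lower one, but its nearest neighbour, compound 1 `ClCc1ccc(Cn2cnc3c(Cl)ncnc32)cc1`, gives 3460 nM in this assay, and the gap between the two falls within the scatter of repeated measurements, so no order between them can be read from the data. Going by the values given here, the two compounds differ in more than one place, so no single-point step between them is counted.

The next compound, compound 3 `ClCc1ccccc1Cn1cnc2c(Cl)ncnc21`, stands apart from compound 2 in one place: hydrogen in place of chloro on an aromatic carbon, or in plain words hydrogen in place of chloro on an aromatic carbon. Among the compounds with values here, no pair of measured compounds shows the effect of this change on its own, so the step of a 1.1-fold higher number from compound 2 to compound 3 (0.03 log units; within the scatter) is only an expectation; it is expected to stay within the scatter and to point in no clear direction. The value for compound 3 in this assay is estimated at 3000 nM, with a range from 1400 nM to 6500 nM.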

Compound 3, concentration for total growth inhibition: 3710 nM
Compound 3: the middle estimate sits 1.2-fold (0.09 log units) below what was measured; the range from low to high includes it.
By their numbers in this assay, from the lowest: compounds 2, 1 and 3 (each within the scatter of the next).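

Going by these compounds alone, the pair of compound 2 and compound 3 is the first to isolate the aromatic carbon between two ring nitrogen atoms: in this assay, hydrogen in place of chloro there gives a 1.3-fold higher number from compound 2 to compound 3 (0.12 log units; within the scatter). On this single pair, then, the chloro group at this carbon is not needed to keep growth inhibition at the level seen for compound 2, since the two compounds cannot be told apart in this measurement. Nothing available speaks to why the exchange leaves the read-out so flat.

What the compounds shown leave open is whether this carbon tolerates any group other than chloro and hydrogen, such as an amine or a methoxy group, and whether this flat result would hold with the chloromethyl group elsewhere on the benzene ring. Going by these compounds, it also remains open what happens at the second chloro group, the one that stays in place in compound 3, if hydrogen or an amine stands there instead.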